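Bromomethyl to 1-bromoethyl in the series

The source may hold more compounds than are shown below. What is called first, only, known or untested is meant among the compounds shown, and "the series" means these compounds.

In a functional assay on A-431 cells (Homo sapiens) for antiproliferative activity, read by sulforhodamine B assay, with a stated time of 72 h (a higher number here means a weaker inhibitor, a lower number a stronger inhibitor), compound 1 `C=C1CC(CBr)(c2ccccc2)OC1=O` gives 1480 nM and sits within the scatter of both measured relatives. Compound 2 `C=C1C[C@](CBr)(c2ccccc2)OC1=O` reads 1330 nM and compound 3 `C=C1CC(CBr)(c2ccc(F)cc2)OC1=O` reads 800 nM on the same read-out.

Compound 4 `C=C1CC(c2ccccc2)(C(C)Br)OC1=O` carries methyl in place of hydrogen on a saturated chain carbon bound to a bromine atom and a saturated ring carbon, the change from bromomethyl to 1-bromoethyl. Within the data shown here, two measured steps bear on it only indirectly: a stereocentre drawn with a configuration gave a 1.1-fold lower number from compound 1 to compound 2 (0.05 log units; within the scatter) and fluoro in place of hydrogen on an aromatic carbon gave a 1.9-fold lower number from compound 1 to compound 3 (0.27 log units; within the scatter) with neither step touching this carbon. Among the measured compounds shown here, both are small, but no measurement yet covers a change at this place.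

In this assay the expected step is a 1.1-fold higher number from compound 1 to compound 4 (0.03 log units; within the scatter) and thus none beyond the scatter, with its direction open. The estimate for compound 4 is 1600 nM (expected range 600 nM to 4500 nM).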

Compound 4, half-maximal inhibitory concentration: 5240 nM
Beside the measured number, compound 4's estimate is 3.3-fold (0.52 log units) below it; the measured number lies above the stated range.
By their numbers in this assay, from the lowest: compounds 3, 2 and 1 (each within the scatter of the next); then compound 4.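

In this assay, the change from bromomethyl to 1-bromoethyl gives a 3.5-fold higher number from compound 1 to compound 4 (0.55 log units; beyond the scatter) and is the only single change shown that lies beyond the scatter, while the steps at the other two places stay within it. The saturated chain carbon bound to a bromine atom and a saturated ring carbon is therefore the first place in the series where one added methyl separates two compounds, though the step is modest. Nothing shown gives a reason for this step, as the only available fact concerns how compounds 1 and 2 are drawn.

Open, going by these compounds, is whether a longer chain such as 1-bromopropyl would extend the same trend, or whether chloromethyl in place of bromomethyl would shift the number at this place. Also open, on these data alone, is whether the methyl step would carry over to the fluoro compound 3.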